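A few compounds are considered here, and "the series" means these few. Any claim that something is new, unique, unknown or untested is made for them only; others in the source may bear on it.

Working notes on the series.

Compound 1 `Cc1cccc2sc(NC(=O)CCN3CCN(c4ccccn4)CC3)nc12` carries a pyridin-2-yl group on the amine nitrogen of its six-membered non-aromatic ring; in an assay on HEK293 cells for antagonist activity at P2X purinoceptor 7 (Homo sapiens), read by fluorescence, with stated times of 30 min and 120 min (a lower number here means a stronger inhibitor, a higher number a weaker inhibitor), compound 1 gives 1400 nM. Compound 2 `Cc1cccc2sc(NC(=O)CCN3CCN(c4ccncc4)CC3)nc12` differs only in that group: a 1.2-fold lower number from compound 1 to compound 2 (0.09 log units; within the scatter). In this assay compound 2 gives 1130 nM. For the measured compounds named here, compound 2 stands with compound 1 on the two numbers so far; their gap lies within the scatter, so neither can be placed ahead of the other.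

Compound 3 `Cc1cccc2sc(NC(=O)CCN3CCN(c4ncccn4)CC3)nc12` is not yet measured. It changes the same position once more: pyrimidin-2-yl in place of pyridin-4-yl on an amine nitrogen in a ring. Going by the values given here, the only measured step that bears on this change is the exchange of one six-membered aromatic group for another on the same ring nitrogen, a 1.2-fold lower number from compound 1 to compound 2 (0.09 log units; within the scatter), which stayed within the scatter. Among the compounds with values here, no step with a two-hetero-atom ring at this position has been measured. On that basis no shift beyond the scatter is expected in this assay for compound 3, in either direction, and the expected step is a 1.0-fold higher number from compound 2 to compound 3 (0.01 log units; within the scatter). The estimate for compound 3 is 1150 nM, with a range of 450 nM to 2900 nM.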

Compound 3, half-maximal inhibitory concentration: 1330 nM
Estimate against measurement, compound 3: 1.2-fold (0.06 log units) below; the range from low to high includes it.
By their numbers in this assay, from the lowest: compounds 2, 3 and 1 (each within the scatter of the next).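

Pyrimidin-2-yl brings the first ring with 2 hetero atoms to this place on the amine nitrogen, and in this assay the exchange gives a 1.2-fold higher number from compound 2 to compound 3 (0.07 log units; within the scatter) and, against the first group tested, a 1.1-fold lower number from compound 1 to compound 3 (0.02 log units; within the scatter). Counted by group, the change adds a ring nitrogen and a hydrogen-bond acceptor at an unchanged count of 6 heavy atoms, and neither step leaves the scatter, so compounds 1, 2 and 3 cannot be separated in this assay and the earlier finding now extends from two pyridinyl groups to a pyrimidinyl group. Nothing measured here accounts for the three groups reading alike.

The compounds shown leave open whether any group on this nitrogen can move the number beyond the scatter, for example a plain phenyl ring with no ring nitrogen, a five-membered aromatic ring such as thiazol-2-yl, or a non-aromatic acetyl group. They also leave open how these same groups would read with a longer chain between the amide carbonyl and the six-membered non-aromatic ring.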